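Urea series, ring-nitrogen rearrangement from compound 2 to compound 3

This account rests on a few compounds, and the source may have more. Where it says the series, first, only, none or still open, it means among the compounds named here.

Compound 2 `O=C(Nc1ccc(-n2ncc3ccncc32)cc1)Nc1ccc(Cl)c(C(F)(F)F)c1` is the weaker of the two measured compounds: in a functional assay on HepG2 cells (Homo sapiens) for cytotoxicity, read by MTT assay, with a stated time of 72 h (on this read-out lower numbers stand for stronger inhibition and higher numbers for weaker inhibition), compound 2 gives 16000 nM, against compound 1 `Cc1cccc2c1cnn2-c1ccc(NC(=O)Nc2ccc(Cl)c(C(F)(F)F)c2)cc1` with 4000 nM. Among the measured compounds shown here, the only measured step in the set, a 4.0-fold higher number from compound 1 to compound 2 (0.60 log units; beyond the scatter), exchanges the whole bicyclic substituent on the shared core and is not a rearrangement within it.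

Compound 3 `O=C(Nc1ccc(-n2ncc3cccnc32)cc1)Nc1ccc(Cl)c(C(F)(F)F)c1` keeps every atom of compound 2 and differs only in how they are joined: a group of 9 heavy atoms (6 carbon, 3 nitrogen; one five-membered aromatic ring with 2 hetero atoms, one six-membered aromatic ring with 1 hetero atom) in place of a group of 9 heavy atoms (6 carbon, 3 nitrogen; one five-membered aromatic ring with 2 hetero atoms, one six-membered aromatic ring with 1 hetero atom), on an aromatic carbon, the place being on an aromatic carbon of a six-membered aromatic ring of carbon only, para to a large group. For the measured compounds named here, no measured pair tests a relocation of a ring nitrogen within an otherwise unchanged bicyclic group, so the step from compound 1 to compound 2 bears on it only as a sign that this region can move the number by a modest amount. Going by the values given here, with no direct precedent, the expectation for compound 3 in this assay is a step of a 1.1-fold lower number from compound 2 to compound 3 (0.06 log units; within the scatter), that is nothing beyond the scatter, and the estimate for compound 3 is 14000 nM with a range of 4000 nM to 45000 nM.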

Compound 3, half-maximal inhibitory concentration: > 32000 nM
Compound 3 was reported as a limit; the forecaster's own chance of this, stated with the estimate: 15%; middle value at least 2.2-fold (0.35 log units) away from the limit.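

Relocating the ring nitrogen inside the bicyclic group, with the same atoms on the same aromatic carbon, is now tested directly: it gives an at least 2.0-fold higher number from compound 2 to compound 3 (0.30 log units; that floor lies within the scatter), and the size of this change cannot be placed beyond the scatter. Set against the group of compound 1, the rearranged group gives an at least 8.0-fold higher number from compound 1 to compound 3 (0.90 log units; beyond the scatter), which runs the same way as a 4.0-fold higher number from compound 1 to compound 2 (0.60 log units; beyond the scatter), so both bicyclic groups with a nitrogen in the six-membered ring stand on the higher side of compound 1 in this assay, and compound 1 remains the only one of the three with a number in the low end of the range shown. The result for compound 3 is a limit of the assay and not a number: the limit of > 32000 nM in this assay, at which 1 of the 3 values shown sits.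

From the compounds shown here alone, how far compound 3 truly lies from compound 2 stays open, as only a floor is available for that step, and the three compounds give no reading of any rearrangement that would lower the number. Also open, going by these compounds, is what an amine or a methoxy group on the six-membered aromatic ring with 1 hetero atom would do to the number in this assay.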